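The source may report more compounds than this note shows. Statements on the series, on what has been measured and on what is new or still open speak of the compounds shown alone.

Measured so far:
compound 1, `CCC(C)(C)C(=O)N(O)Cc1ccc(F)c(F)c1F`, 13.1 uL/min
compound 2, `CCC(C)(C)C(=O)N(O)Cc1cc(F)c(F)c(F)c1`, 10.5 uL/min
compound 3, `CCC(C)(C)C(=O)N(O)Cc1ccc(F)cc1`, 3.9 uL/min

Among these three, compound 3 gives the lowest number; compound 2 and compound 1 both stand higher, each beyond the usual scatter. Compound 4, `CCC(C)(C)C(=O)N(O)Cc1ccc(F)c(F)c1`, has not been measured. It differs from compound 3 in one place: fluoro in place of hydrogen on an aromatic carbon. Going by the values given here, no pair of measured compounds differs in just one place, so this step has no direct precedent. Fluoro for hydrogen on the same ring is the direction taken from compound 3 toward compound 1 and compound 2, both of which give higher numbers, so in an ADME assay on microsomes from liver (Homo sapiens) for metabolic stability, read by LC-MS, using NADPH (a lower number here means slower removal, a higher number faster removal of the compound), an upward step of moderate size is expected, likely beyond the scatter yet short of those two. Compound 4 is expected to give 7 uL/min, in the range 3.5 uL/min to 14 uL/min, meaning an expected step of a 1.8-fold higher number from compound 3 to compound 4 (0.25 log units; within the scatter).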

Compound 4, intrinsic clearance in a liver preparation (reported as CLH), per the amount of preparation that the assay uses: 6.5 uL/min
Compound 4: middle estimate off by 1.1-fold (0.03 log units), on the high side; low and high end bracket the measured number.
By their numbers in this assay, from the lowest: compounds 3, 4, 2 and 1 (each within the scatter of the next, the first and the last beyond it).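

Fluoro in place of hydrogen on this aromatic carbon, ortho to a fluoro group, gives in this assay a 1.7-fold higher number from compound 3 to compound 4 (0.22 log units; within the scatter) and does not separate the two compounds. Hydrogen in place of fluoro likewise gives a 1.6-fold lower number from compound 2 to compound 4 (0.21 log units; within the scatter) and a 2.0-fold lower number from compound 1 to compound 4 (0.30 log units; within the scatter) and separates neither pair, so each single fluoro step read here stays small, though the fluoro count differs between these compounds. Nothing measured here bears on the reason for these steps.

As far as these compounds go, whether chloro, methoxy or a nitrile on this aromatic carbon would give a step beyond the scatter remains open. So does the effect of an amine or a longer chain elsewhere on the shared core.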